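This account rests on a few compounds, and the source may have more. Where it says the series, first, only, none or still open, it means among the compounds named here.

Compound 1 `Nc1ccccc1NC(=O)CCCNCC(=O)Nc1ccc(Cl)cc1` and compound 2 `Nc1ccccc1NC(=O)CCCNCC(=O)Nc1cccc([N+](=O)[O-])c1` share one core and differ only in the group carried on an amide-type nitrogen. In a functional assay on U-251 cells (Homo sapiens) for inhibition, read by MTT assay, with a stated time of 2 days (on this read-out lower numbers stand for higher toxicity in this test and higher numbers for lower toxicity in this test), compound 1 gives > 100000 nM, which is a limit of the assay and not a number. In this assay compound 2 gives > 100000 nM, likewise a limit rather than a measured number. For the measured compounds named here, the single measured step, a step that the two limits leave unreadable from compound 1 to compound 2, therefore has no readable size, and compound 2 stands at the limit of > 100000 nM in this assay, at which 2 of the 2 values shown sit, together with compound 1. Compound 3 `COc1ccc(NC(=O)CNCCCC(=O)Nc2ccccc2N)cc1` differs from compound 2 in one place: 4-methoxyphenyl in place of 3-nitrophenyl on an amide-type nitrogen. This change on the amide-type nitrogen has the step from compound 1 to compound 2 as its only measured relative, and that step is unreadable because both of its values sit at the limit of > 100000 nM in this assay, at which 2 of the 2 values shown sit. No step beyond the scatter in either direction can be expected from such evidence, and the most likely outcome for compound 3 in this assay is expected to be another limit. Compound 3 is thus expected to show a step that the limit leaves unreadable from compound 2 to compound 3 in this assay. Compound 3 is estimated at 150000 nM, with a range from 60000 nM to 400000 nM.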

Compound 3, concentration lethal to 50% of the cells: > 100000 nM
Compound 3: a limit, no number; the forecaster's own chance of this, stated with the estimate: 85%; the middle value is on the limit's open side.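

In this assay compound 3 gives > 100000 nM, a limit of the assay and not a number. For the compounds shown here, no step among compound 1, compound 2 and compound 3 can therefore be read, as each compound stands at the same place: the limit of > 100000 nM in this assay, at which 3 of the 3 values shown sit. The compounds shown leave open whether any group on the amide-type nitrogen changes this read-out at all.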